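The compounds below may be only part of what the source reports. "The series", "measured", "known", "first", "only" and "open" are said of these compounds alone.

In a functional assay on HepG2 cells (Homo sapiens) for inhibition, read by MTT assay, with a stated time of 3 days (on this read-out higher numbers stand for weaker inhibition and lower numbers for stronger inhibition), compound 1 `COc1cc(-c2nc3ccccc3s2)ccc1OCC(=O)NNC(=O)CN[C@@H](CS(=O)(=O)O)C(=O)O` gives 3690 nM and compound 2 `CCOC(=O)[C@@H](NCC(=O)NNC(=O)COc1ccc(-c2nc3ccccc3s2)cc1OC)[C@@H](C)CC` gives 3460 nM. Among the compounds with values here, these are the only two numbers so far, and they lie within the scatter of each other, so compound 2 stands level with compound 1. Compound 3 `CCOC(=O)[C@H](CCSC)NCC(=O)NNC(=O)COc1ccc(-c2nc3ccccc3s2)cc1OC`, still unmeasured, carries 2-(methylsulfanyl)ethyl in place of sec-butyl on a saturated chain carbon bound to an amine nitrogen and a carbonyl carbon. Within the data shown here, the one measured step that bears on this is a 1.1-fold lower number from compound 1 to compound 2 (0.03 log units; within the scatter). There, 1-(ethoxycarbonyl)-2-methylbutyl took the place of 1-carboxy-2-sulfoethyl on the amine nitrogen, a change to the same side chain. Given that step, no change beyond the scatter is expected in this assay here. Compound 3 is expected at 3300 nM, with an estimated range of 1600 nM to 6500 nM. The estimate means an expected 1.0-fold lower number from compound 2 to compound 3 (0.02 log units; within the scatter).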

Compound 3, half-maximal inhibitory concentration: 3330 nM
For compound 3 the middle estimate is 1.0-fold (0.00 log units) below the measured one; the range from low to high includes it.
By their numbers in this assay, from the lowest: compounds 3, 2 and 1 (each within the scatter of the next).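

In this assay, the side chain alone changes on the saturated chain carbon bound to an amine nitrogen and a carbonyl carbon: 2-(methylsulfanyl)ethyl in place of sec-butyl gives a 1.0-fold lower number from compound 2 to compound 3 (0.02 log units; within the scatter), so these two side chains cannot be told apart at this position. The larger exchange on the amine nitrogen, 1-(ethoxycarbonyl)-3-(methylsulfanyl)propyl in place of 1-carboxy-2-sulfoethyl, gives a 1.1-fold lower number from compound 1 to compound 3 (0.04 log units; within the scatter), a second replacement of that group that also stays level. Nothing measured here speaks to why these numbers stay level. As far as these compounds go, whether a benzyl group or a 4-aminobutyl chain on this carbon would shift the number beyond the scatter remains open. So does the effect of a free carboxylic acid in place of the ethyl ester with the side chain held fixed.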